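Amide aryl variation on a shared core: weak antiproliferation

A few compounds are considered here, and "the series" means these few. Any claim that something is new, unique, unknown or untested is made for them only; others in the source may bear on it.

Measured so far:
- compound 1 `O=C(Nc1ccc(Cl)c(-c2nnc3c(Cl)cccn23)c1)c1ccc(C(F)(F)F)cc1F`: 70800 nM
- compound 2 `Cc1nc(C(=O)Nc2ccc(Cl)c(-c3nnc4c(Cl)cccn34)c2)cs1`: > 100000 nM, a limit of the assay
- compound 3 `O=C(Nc1ccc(Cl)c(-c2nnc3c(Cl)cccn23)c1)c1ccccc1Cl`: 83800 nM

In a functional assay on T47D cells (Homo sapiens) for antiproliferative activity, read by MTT assay, with a stated time of 72 h (on this read-out higher numbers stand for weaker inhibition and lower numbers for stronger inhibition), compound 1 gives 70800 nM. Compound 2 reaches only the limit > 100000 nM in this assay, so no number is known for it. Compound 3 gives 83800 nM, the higher of the two numbers; compound 1 sits within the scatter of it, so the two are not distinguished. Among the compounds with values here, the only single-point step measured is an at least 1.1-fold lower number from compound 2 to compound 3 (0.07 log units; that floor lies within the scatter), which starts from a limit and is a floor only; the limit of > 100000 nM in this assay, at which 1 of the 3 values shown sits, is the boundary that compound 2 sits at.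

Compound 4 `O=C(Nc1ccc(Cl)c(-c2nnc3c(Cl)cccn23)c1)c1ccccn1` differs from compound 3 by pyridin-2-yl in place of 2-chlorophenyl on a carbonyl carbon. Within the data shown here, no measured step bears directly on this exchange; the one comparison available, a heteroaryl against a chlorophenyl on the carbonyl carbon, gave a difference that cannot be separated from the scatter. The whole set is weakly active, and the amide aryl group has so far moved the number little. The expected step is therefore a 1.0-fold higher number from compound 3 to compound 4 (0.01 log units; within the scatter), with no clear direction. The estimate for compound 4 in this assay is 85000 nM, in a range from 40000 nM to 200000 nM, with a real chance that only a limit is returned.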

Compound 4, half-maximal inhibitory concentration: > 100000 nM
Compound 4: no number, only a limit; the forecaster's own chance of this, stated with the estimate: 35%; middle value at least 1.1-fold (0.07 log units) from the limit.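

Pyridin-2-yl in place of 2-chlorophenyl on a carbonyl carbon gives an at least 1.1-fold higher number from compound 3 to compound 4 (0.07 log units; that floor lies within the scatter) as its only reading, and as a floor this leaves the true size of the step unknown. Compound 4 returns a limit and not a number in this assay, and the step between compound 2 and compound 4 cannot be read, since both ends are limits. Of the four amides, the two carrying a ring with hetero atoms, compound 2 and compound 4, are the two that return no number, whereas compound 1 and compound 3, with substituted phenyl groups, return numbers, and no compound shown goes against this split, which rests on: the limit of > 100000 nM in this assay, at which 2 of the 4 values shown sit.

Pyridin-2-yl differs from 2-chlorophenyl both by the ring nitrogen and by the loss of the chlorine, so the compounds shown do not tell these two changes apart, and an unsubstituted phenyl group on the carbonyl carbon would be the comparison that bears on this. Also open, going by these compounds, is whether any group on the carbonyl carbon, such as a phenyl ring carrying an amine or a carboxylic acid, moves the number far from where this series sits.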